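The source may hold more compounds than are shown below. What is called first, only, known or untested is meant among the compounds shown, and "the series" means these compounds.

Measured compounds in a functional assay on KB cells (Homo sapiens) for cytotoxicity, read by sulforhodamine B assay, with a stated time of 48 h; a higher number here means a weaker inhibitor of growth, a lower number a stronger inhibitor of growth:
- compound 1 `Cc1cnc(NC(=O)COc2ccc(/C=C3\SC(=O)NC3=O)cc2)s1`; compound 1 gives < 100000 nM, a limit of the assay.
- compound 2 `O=C(COc1ccc(/C=C2\SC(=O)NC2=O)cc1)Nc1cccc(C(F)(F)F)c1`; compound 2 gives < 100000 nM, a limit of the assay.
- compound 3 `O=C(COc1ccc(/C=C2\SC(=O)NC2=O)cc1)Nc1nc2ccccc2s1`; compound 3 gives < 100000 nM, a limit of the assay.

Compound 3 stands at a limit only; the two further values shown are limits as well (the limit of < 100000 nM in this assay, at which 3 of the 3 values shown sit). For the measured compounds named here, the single step between measured compounds that differ in one place, a step that the two limits leave unreadable from compound 1 to compound 3, is left unreadable by the two limits. Compound 4 `O=C(COc1ccc(/C=C2\SC(=O)NC2=O)cc1)Nc1ncc([N+](=O)[O-])s1` differs from compound 3 in one place: 5-nitro-1,3-thiazol-2-yl in place of 1,3-benzothiazol-2-yl on an amide-type nitrogen. Going by the values given here, no measured step bears on this change with a readable size, so no step in this assay beyond the scatter can be expected in either direction, and a further limit is the likelier outcome. Compound 4 is therefore estimated at 30000 nM (3000 nM to 100000 nM), which means an expected step that the limit leaves unreadable from compound 3 to compound 4.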

Compound 4, concentration for total growth inhibition: < 100000 nM
Compound 4 was reported as a limit (the forecaster's own chance of this, stated with the estimate: 70%); the middle value is on the limit's open side.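

For the compounds shown here, compound 4 is a limit, as are compound 1 and compound 3, so no step among them can be read: the limit of < 100000 nM in this assay, at which 4 of the 4 values shown sit. The compounds shown leave open where each actual value lies and whether these substituent changes alter growth inhibition.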